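Three-ring amine series: half-life in mouse liver microsomes

The source may hold more compounds than are shown below. What is called first, only, known or untested is meant among the compounds shown, and "the series" means these compounds.

Three compounds of this series have been run in an ADME assay on microsomes from liver (Mus musculus) for metabolic stability, read by LC-MS, using NADPH, with a stated time of 10 min, tested at 10 uM; a higher number here means that the compound lasts longer, a lower number that the compound disappears faster. Compound 1 `Nc1ncnc2c1c(Oc1cccc(C(F)(F)F)c1)nn2[C@H]1C[C@H](O)C1` gives 0.367 h in this assay. Compound 2 `CO[C@H]1CC[C@H](n2nc(Oc3cc(C(F)(F)F)ccn3)c3c(N)ncnc32)CC1` gives 0.217 h in this assay. Compound 3 `Cc1cccc(Oc2nn(C(C)(C)C)c3ncnc(N)c23)c1` gives 0.0717 h in this assay. Among these three numbers, compound 2 sits in the middle: its nearest neighbour is compound 1, whose number is within the scatter of repeated measurements, while compound 3 is the furthest off, with a number beyond the scatter and lower than that of compound 2. No pair of these compounds differs in a single place, so no step between measured compounds can be quoted.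

Compound 4 `Nc1ncnc2c1c(Oc1cc(C(F)(F)F)ccn1)nn2[C@@H]1CC[C@H](N)C1` has not yet been measured in this assay. It differs from compound 2 as follows: 3-aminocyclopentyl in place of 4-methoxycyclohexyl on an aromatic nitrogen. The aromatic nitrogen carrying the group is the one next to the ring nitrogen of the five-membered aromatic ring, two ring bonds from the ring atom that bears a large group.

Within the data shown here, with no measured step for this kind of change, the expectation rests on compound 2 alone. The step from compound 2 to compound 4 is estimated to be small, a 1.4-fold higher number from compound 2 to compound 4 (0.14 log units; within the scatter), and not beyond the scatter in either direction. For compound 4 the half-life in this assay is expected to be about 0.3 h, with a range from 0.13 h to 0.7 h.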

Compound 4, half-life: 1.4 h
Beside the measured number, compound 4's estimate is 4.7-fold (0.67 log units) below it; measured number outside the range, above it.
By their numbers in this assay, from the lowest: compound 3; then compounds 2 and 1 (each within the scatter of the next); then compound 4.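

In this assay, the group on the aromatic nitrogen, next to the ring nitrogen, can move the half-life well beyond the scatter: 3-aminocyclopentyl in place of 4-methoxycyclohexyl gives a 6.5-fold higher number from compound 2 to compound 4 (0.81 log units; beyond the scatter). Among these compounds, this is the only step that isolates a single place, and it shows that this position matters for the read-out with the rest of compound 2 held fixed. The swap changes ring size, removes the methoxy group and brings in an amine all at once, so the step belongs to the change as a whole, and no measurement here accounts for it.

Which part of the change carries the step stays open: an aminocyclohexyl group would keep the amine on the six-membered ring, and a hydroxycyclopentyl group would keep the five-membered ring with a hydroxyl in place of the amine. Also open, going by these compounds, is whether the same swap gives a step of similar size with the other aryl ether of compound 1, where the trifluoromethyl group sits on a phenyl ring.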